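From phenyl to 3,4-difluorophenyl on an amide-type nitrogen

A few compounds are considered here, and "the series" means these few. Any claim that something is new, unique, unknown or untested is made for them only; others in the source may bear on it.

Compound 1 `C=C(Br)C(=O)Nc1cccc(/C=C/C(=O)Nc2ccccc2)c1`: 1100 nM
Compound 2 `C=C(Br)C(=O)Nc1cccc(/C=C/C(=O)Nc2cccc3ccccc23)c1`: 830 nM

In a functional assay on SEM cells (Homo sapiens) for inhibition, read by MTT assay, with a stated time of 72 h (a higher number here means a weaker inhibitor, a lower number a stronger inhibitor), compound 1 gives 1100 nM, and compound 2, with a different group on the same nitrogen, lies within the usual scatter of it. Neither value can be ranked above the other.

Compound 3 `C=C(Br)C(=O)Nc1cccc(/C=C/C(=O)Nc2ccc(F)c(F)c2)c1` keeps the core of compound 1 and has 3,4-difluorophenyl in place of phenyl on an amide-type nitrogen. Among the measured compounds shown here, no measured pair shows this exact change, so the expectation is loose. The expected size of the change, a 1.2-fold lower number from compound 1 to compound 3 (0.09 log units; within the scatter), is none beyond the scatter. For compound 3 the estimate is 900 nM, with an expected range of 350 nM to 2300 nM.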

Compound 3, half-maximal inhibitory concentration: 90 nM
The estimate for compound 3 lay 10-fold (1.00 log units) above the measured number; measured number outside the range, below it.
By their numbers in this assay, from the lowest: compound 3; then compounds 2 and 1 (each within the scatter of the next).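

In this assay, the group on this amide-type nitrogen turns out to matter greatly: 3,4-difluorophenyl in place of phenyl gives a 12-fold lower number from compound 1 to compound 3 (1.09 log units; beyond the scatter). Among the compounds shown here, compound 2 showed no separation from compound 1, so this is the first sign that a change at this position can move the number beyond the scatter. Nothing measured here accounts for the step.

On these data alone, whether each fluorine is needed remains open. So does whether a chlorophenyl or methoxyphenyl group on the same nitrogen would give a similarly low number.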